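This account rests on a few compounds, and the source may have more. Where it says the series, first, only, none or still open, it means among the compounds named here.

The set holds three measured compounds and one awaiting measurement. Going by the values given here, compound 1 `O=C(Nc1cc2cccccc-2c1)c1cccnc1` gives 2 ug/mL in a physicochemical assay for solubility, with a stated time of 24 h, at pH 6.8 (a lower number here means a less soluble compound, a higher number a more soluble compound), the only plain number among the three. Compound 3 `O=C(Cn1ccccc1=O)Nc1cc2ccccc2[nH]1` is reported in this assay only as a limit, where compound 3 gives > 67 ug/mL. Compound 2 `CN(C)C(=O)c1cn(C)c2ccccc12` likewise stands at a limit in this assay, where compound 2 gives > 51 ug/mL. So compound 2 sits at a limit, with no number to place it, and no measured pair of compounds differing in a single place is available to guide the next step.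

Compound 4 `COC(=O)c1ccc2c(C(=O)N(C)C)cn(C)c2c1` differs from compound 2 by methoxycarbonyl in place of hydrogen on an aromatic carbon, on an aromatic carbon of a six-membered aromatic ring of carbon only, part of a fused system of two rings. The step of an at least 2.0-fold lower number from compound 2 to compound 4 (0.30 log units; that floor lies within the scatter) is expected to be a moderate fall, somewhat beyond the scatter, though the limit for compound 2 leaves its true size uncertain. Compound 4 is estimated at 25 ug/mL, with a range from 6 ug/mL to 80 ug/mL.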

Compound 4, solubility: 49 ug/mL
The estimate for compound 4 lay 2.0-fold (0.29 log units) below the measured number, and the stated range covers the measured number.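

The set now holds its first step between compounds that differ in one place, methoxycarbonyl in place of hydrogen on an aromatic carbon, and in this assay it reads as an at least 1.0-fold lower number from compound 2 to compound 4 (0.01 log units; that floor lies within the scatter). Compound 4 also gives this core its first plain number, so a group at this position, meta to a fused ring and para to a fused ring, can now be tied to a value rather than to a limit alone. The true size of the step stays unknown, since its starting point is a limit and not a number: the limit of > 51 ug/mL in this assay, at which 1 of the 4 values shown sits.

The compounds shown leave open whether the number truly drops at this position, or by how much. They also leave open how a carboxylic acid or an amine at the same carbon would compare with methoxycarbonyl, and whether the other carbons of this ring would respond in the same way.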